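Taking One Nitro Group off Compound 1

The compounds below may be only part of what the source reports. "The series", "measured", "known", "first", "only" and "open" are said of these compounds alone.

Compound 1 `O=C(NNC(=O)c1cc([N+](=O)[O-])c[nH]1)Nc1ccc([N+](=O)[O-])cc1` is one of three compounds tested in an ADME assay on Vero cells (Chlorocebus sabaeus) for cytotoxicity, read by MTT assay, with a stated time of 72 h (on this read-out higher numbers stand for weaker inhibition and lower numbers for stronger inhibition), where compound 1 gives 211000 nM. Compound 2 `Cn1cc([N+](=O)[O-])cc1C(=O)NNC(=S)NCc1ccccc1` gives 239000 nM, and compound 3 `Cn1cc([N+](=O)[O-])cc1C(=O)NNC(=S)NC1CCCCC1` gives 352000 nM. The three numbers sit close together, and every gap between them lies within the usual scatter of repeated measurements, so compound 1 cannot be set apart from the other two on these data. Among the compounds with values here, the only step between two measured compounds that differ in a single place is a 1.5-fold higher number from compound 2 to compound 3 (0.17 log units; within the scatter), and that step also stays within the scatter.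

Compound 4 `O=C(NNC(=O)c1cc([N+](=O)[O-])c[nH]1)Nc1ccccc1` differs from compound 1 in one place: hydrogen in place of nitro on an aromatic carbon. Within the data shown here, no measured step involves a nitro group, and the single available step concerns a different group on a different compound, so nothing points in either direction. The change is therefore expected to give a step of a 1.2-fold higher number from compound 1 to compound 4 (0.07 log units; within the scatter), which means none beyond the scatter. Compound 4 is estimated at 250000 nM, with a range from 120000 nM to 520000 nM.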

Compound 4, half-maximal inhibitory concentration: 357000 nM
For compound 4 the middle estimate is 1.4-fold (0.15 log units) below the measured one, and the stated range covers the measured number.
By their numbers in this assay, from the lowest: compounds 1, 2, 3 and 4 (each within the scatter of the next).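

Taking the nitro group off the six-membered aromatic ring, at the place para to a large group, gives a 1.7-fold higher number from compound 1 to compound 4 (0.23 log units; within the scatter) in this assay. Within the data shown here, this is the first step in this set that tests this position directly, and it shows that compound 4 cannot be told apart from compound 1 on this read-out, even though the change removes three heavy atoms and both hydrogen-bond acceptors of the nitro group. The data give no measured property that bears on this result.

From the compounds shown here alone, whether another group at this place, such as an amine or a carboxylic acid, would move the number beyond the scatter remains open. Also open, going by these compounds, is what the other nitro group of compound 1 contributes, since these compounds do not isolate a change at that site.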